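From a Methoxy to a Hydroxy Group

A few compounds are considered here, and "the series" means these few. Any claim that something is new, unique, unknown or untested is made for them only; others in the source may bear on it.

Compound 1 `COc1cc(/C=C/C(=O)Nc2cc3c(Nc4ccc(F)c(Cl)c4)ncnc3cc2O[C@H]2CCOC2)cc(OC)c1OC` gives 24500 nM
Compound 2 `COc1cc2ncnc(Nc3ccc(F)c(Cl)c3)c2cc1NC(=O)/C=C/c1ccccc1[N+](=O)[O-]` gives "not determined" (no result reported)
Compound 3 `COc1cc2ncnc(Nc3ccc(F)c(Cl)c3)c2cc1NC(=O)/C=C/c1cc(OC)c(OC)c(OC)c1` gives "not determined" (no result reported)

Within the data shown here, in a functional assay on HeLa cells (Homo sapiens) for cytotoxicity, read by MTT assay, with a stated time of 72 h (on this read-out lower numbers stand for stronger inhibition and higher numbers for weaker inhibition), compound 1 gives 24500 nM, and this is the only number available, so it cannot be ranked against any other compound. Compound 2 has the entry "not determined" (no result reported), and compound 3 has the entry "not determined" (no result reported).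

Compound 4 `COc1cc(/C=C/C(=O)Nc2cc3c(Nc4ccc(F)c(Cl)c4)ncnc3cc2O[C@H]2CCOC2)cc(OC)c1O` departs from compound 1 at one place: hydrogen in place of methyl on an oxygen on an aromatic ring. This is hydrogen in place of methyl on an oxygen on an aromatic ring, which turns 3,4,5-trimethoxyphenyl to 4-hydroxy-3,5-dimethoxyphenyl.

Among the measured compounds shown here, no measured pair shows what this change does, and no other measured pair offers a step for comparison. The expectation therefore rests on compound 1 at 24500 nM alone. No step beyond the scatter is expected in this assay, and neither direction is firmly favoured.

The estimate implies an expected 1.2-fold lower number from compound 1 to compound 4 (0.09 log units; within the scatter). For compound 4 the expected value is 20000 nM, with an estimated range from 7000 nM to 55000 nM.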

Compound 4, half-maximal inhibitory concentration: 27400 nM
Compound 4: the middle estimate sits 1.4-fold (0.14 log units) below what was measured; the measured number falls inside the stated range.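

In this assay, the change from methoxy to hydroxy, which turns 3,4,5-trimethoxyphenyl to 4-hydroxy-3,5-dimethoxyphenyl, gives a 1.1-fold higher number from compound 1 to compound 4 (0.05 log units; within the scatter). Among these compounds, this is the first step that can be read at this position, and it shows that on this read-out the methyl on this oxygen can give way to hydrogen with no difference that stands out from the scatter. No available evidence bears on this result.

Compounds 2 and 3 carry no numbers, so steps involving them cannot be read. The compounds shown leave open whether a larger change at this position, such as an amine or a carboxylic acid in place of the hydroxy, would give a step beyond the scatter.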